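This account rests on a few compounds, and the source may have more. Where it says the series, first, only, none or still open, it means among the compounds named here.

Of the compounds shown here, three that share one core have been read in a functional assay on MCF7 cells (Homo sapiens) for antiproliferative activity, read by MTT assay, with a stated time of 48 h; on this read-out lower numbers stand for stronger inhibition and higher numbers for weaker inhibition. There, compound 1 `COc1cc(/C=C/c2nnc(NC(=O)c3ccccc3Br)s2)c(Br)c(OC)c1OC` gives 370 nM, compound 2 `COc1cc(/C=C/c2nnc(NC(=O)c3ccc(Br)cc3)s2)c(Br)c(OC)c1OC` gives 320 nM and compound 3 `COc1cc(/C=C/c2nnc(NC(=O)c3cccc(Cl)c3)s2)c(Br)c(OC)c1OC` gives 230 nM. Compound 2 cannot be separated from either of the others on these numbers: the steps read a 1.2-fold lower number from compound 1 to compound 2 (0.06 log units; within the scatter) and a 1.4-fold lower number from compound 2 to compound 3 (0.14 log units; within the scatter).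

Compound 4 `COc1cc(/C=C/c2nnc(NC(=O)c3cccc(F)c3)s2)c(Br)c(OC)c1OC` has not yet been measured. Its difference from compound 2 is 3-fluorophenyl in place of 4-bromophenyl on a carbonyl carbon. Among the measured compounds shown here, three measured steps bear on this change, since each exchanges one substituted phenyl for another at that same place. The closest is the exchange of 4-bromophenyl for 3-chlorophenyl, a 1.4-fold lower number from compound 2 to compound 3 (0.14 log units; within the scatter). The other two are a 1.2-fold lower number from compound 1 to compound 2 (0.06 log units; within the scatter) and a 1.6-fold lower number from compound 1 to compound 3 (0.21 log units; within the scatter). None of them leaves the scatter, so no step beyond the scatter is expected in this assay, in either direction. The estimated step is a 1.1-fold lower number from compound 2 to compound 4 (0.06 log units; within the scatter). For compound 4 the expected value is 280 nM, with an estimated range from 130 nM to 600 nM.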

Compound 4, half-maximal inhibitory concentration: 340 nM
Estimate against measurement, compound 4: 1.2-fold (0.08 log units) below; low and high end bracket the measured number.
By their numbers in this assay, from the lowest: compounds 3, 2, 4 and 1 (each within the scatter of the next).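

In this assay the 3-fluorophenyl group on the carbonyl carbon cannot be separated from any of the three other halogen-bearing phenyls: the steps read a 1.1-fold higher number from compound 2 to compound 4 (0.03 log units; within the scatter) and a 1.1-fold lower number from compound 1 to compound 4 (0.04 log units; within the scatter) and also a 1.5-fold higher number from compound 3 to compound 4 (0.17 log units; within the scatter) and each stays within the scatter. Among the compounds shown here, the last of these adds the first direct exchange of fluoro for chloro on an aromatic carbon, and across these four compounds neither the halogen nor its printed place on the phenyl moves the number beyond the scatter. Nothing available explains why these compounds read so alike.

Still open, as far as these compounds go, is whether this holds for substituents other than halogens, such as a methoxy group, an amine or a carboxylic acid on the phenyl. Also open, from the compounds shown here alone, is how an unsubstituted phenyl or a cyclohexyl group would read at this place.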